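The compounds below may be only part of what the source reports. "The series", "measured", "known", "first", "only" and "open" are said of these compounds alone.

Working notes on the series. Compound 1 `O=C(Nc1nnc(-c2cccc(O)c2O)s1)c1ccccc1` gives 20700 nM in a functional assay on HL-60 cells (Homo sapiens) for cytotoxicity, read by MTT assay, with a stated time of 72 h; on this read-out lower numbers stand for stronger inhibition and higher numbers for weaker inhibition. Compound 2 `CC(=O)Nc1nnc(-c2ccc(O)c(O)c2)s1` gives 42500 nM, the highest of the three numbers. Compound 3 `O=C(COc1ccccc1)Nc1nnc(-c2cccc(O)c2O)s1` gives 11200 nM. Compound 4 `Cc1ccc(C(=O)Nc2nnc(-c3ccc(O)c(O)c3)s2)cc1` is not yet measured; it differs from compound 2 by 4-methylphenyl in place of methyl on a carbonyl carbon. Going by the values given here, the only measured step on the carbonyl carbon, a 1.8-fold lower number from compound 1 to compound 3 (0.27 log units; within the scatter), also enlarged the group there and stayed within the scatter. Compound 1, carrying phenyl on the carbonyl carbon, gives 20700 nM; compound 2, carrying methyl there, gives 42500 nM. A small step to a lower number is therefore expected in this assay, about a 2.1-fold lower number from compound 2 to compound 4 (0.33 log units; beyond the scatter), with no step beyond the scatter excluded. Compound 4 is estimated at 20000 nM, expected between 7000 nM and 50000 nM.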

Compound 4, half-maximal inhibitory concentration: 10500 nM
Beside the measured number, compound 4's estimate is 1.9-fold (0.28 log units) above it; the range from low to high includes it.
By their numbers in this assay, from the lowest: compounds 4, 3 and 1 (each within the scatter of the next); then compound 2.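

The change from methyl to 4-methylphenyl on a carbonyl carbon gives a 4.0-fold lower number from compound 2 to compound 4 (0.61 log units; beyond the scatter) in this assay and is a modest step. It is the first step at this place shown beyond the scatter, whereas a 1.8-fold lower number from compound 1 to compound 3 (0.27 log units; within the scatter) stayed within it. Still open, as far as these compounds go, is whether the lower number follows the aromatic ring or its methyl, which plain phenyl on the core of compound 2 would separate, and how a longer chain or an amine on the carbonyl carbon would read. No measurement at hand accounts for the step.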